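The source may hold more compounds than are shown below. What is called first, only, known or untested is meant among the compounds shown, and "the series" means these compounds.

Compound 1, `CCCCCCCCc1ccc(OC(C)C(=O)Cn2nnc(-c3ccc(C(=O)OC)cc3)n2)cc1`, gives in a physicochemical assay for lipophilicity, read by HPLC, tested at 5 mM (on this read-out higher numbers stand for higher lipophilicity and lower numbers for lower lipophilicity), a value that is only a limit of the assay, > 8.
Compound 2, `COC(=O)c1ccc(-c2nnn(CC(=O)C(C)Oc3ccc(Oc4ccc(C(F)(F)F)cc4)cc3)n2)cc1`, gives in this assay 6.2.
Compound 3, `COC(=O)c1ccc(-c2nnn(CC(=O)C(C)Oc3ccc(-c4ccccc4)cc3)n2)cc1`, gives in this assay 5.4.

Among the two plain numbers, compound 3 stands lowest; its nearest neighbour is compound 2, and the step of a number 0.80 log units lower from compound 2 to compound 3 (beyond the scatter) lies beyond the scatter. Compound 4, `CC(Oc1ccc(-c2ccccc2)cc1)C(=O)Cn1nnc(-c2ccc(C(=O)O)cc2)n1`, differs from compound 3 by hydrogen in place of methyl on an oxygen next to a carbonyl group. The measured steps, a number at least 1.80 log units lower from compound 1 to compound 2 (beyond the scatter), a number at least 2.60 log units lower from compound 1 to compound 3 (beyond the scatter) and a number 0.80 log units lower from compound 2 to compound 3 (beyond the scatter), all exchange the group on the aromatic carbon and leave the oxygen next to the carbonyl untouched, so none of them tests this change directly. The step of a number 2.00 log units lower from compound 3 to compound 4 (beyond the scatter) is therefore an expectation rather than a reading from the data. Compound 4 is estimated at 3.4, with a likely range from 2.4 to 4.4.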

Compound 4, partition coefficient: 2.6
Compound 4: middle estimate off by 0.80 log units, on the high side; low and high end bracket the measured number.
By their numbers in this assay, from the lowest: compound 4; then compound 3; then compound 2. At a limit, above all of these: compound 1.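

Every earlier step changed the group on the aromatic carbon and left the methoxycarbonyl group untouched. Changing methoxycarbonyl to carboxy gives, in this assay, a number 2.80 log units lower from compound 3 to compound 4 (beyond the scatter), so this end of the molecule also moves the read-out. That single methyl-to-hydrogen change outweighs the earlier exchange on the aromatic carbon, a number 0.80 log units lower from compound 2 to compound 3 (beyond the scatter).

Going by these compounds, whether an ethyl ester or a primary amide at this place would read closer to compound 3 or to compound 4 stays open. Compound 1 remains only a limit, which leaves the same change on its octyl series unanchored: the limit of > 8 in this assay, at which 1 of the 4 values shown sits.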